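Cyclopropyl for isopropyl on a ring amine nitrogen

This account rests on a few compounds, and the source may have more. Where it says the series, first, only, none or still open, it means among the compounds named here.

Measured in an ADME assay on microsomes from liver (Rattus norvegicus) for metabolic stability, read by LC-MS, with a stated time of 10 min, tested at 0.5 uM; a lower number here means that less of the compound is left, a higher number that more of the compound is left
compound 1 `c1ccc2c(c1)CN[C@@H](CN(CCCN1CCNCC1)[C@H]1CCCc3cccnc31)C2` gives 100%
compound 2 `CC(C)N1CCN(CCCN(C[C@H]2Cc3ccccc3CN2)[C@H]2CCCc3cccnc32)CC1` gives 4%

Compound 2 stands lowest of the two measured compounds, at 4%, so little room remains below it. Compound 3 `c1ccc2c(c1)CN[C@@H](CN(CCCN1CCN(C3CC3)CC1)[C@H]1CCCc3cccnc31)C2` differs from it as follows: cyclopropyl in place of isopropyl on an amine nitrogen in a ring. Within the data shown here, only one measured step bears on this place, with isopropyl in place of hydrogen: a number 96 percentage points lower from compound 1 to compound 2 (beyond the scatter), large and beyond the scatter. Among the measured compounds shown here, no measured step exchanges one substituent for another here, so the evidence is thin. In this assay a moderate rise, much smaller than that step, is expected. The expected change is a number 21 percentage points higher from compound 2 to compound 3 (beyond the scatter). The estimate for compound 3 is 25%, with an expected range of 6% to 65%.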

Compound 3, percent of the compound remaining: 2%
For compound 3 the middle estimate is 23 percentage points above the measured one; the measured number lies below the stated range.
By their numbers in this assay, from the lowest: compounds 3 and 2 (each within the scatter of the next); then compound 1.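

In this assay cyclopropyl in place of isopropyl on the amine nitrogen in the ring gives a number 2 percentage points lower from compound 2 to compound 3 (within the scatter) and so does not separate the two groups, despite the added three-membered ring. Cyclopropyl in place of hydrogen gives a number 98 percentage points lower from compound 1 to compound 3 (beyond the scatter) and thus matches the large step already seen with isopropyl, so the low number is not specific to isopropyl. No supporting data explain these numbers.

Still open, as far as these compounds go, is whether a smaller methyl group or an acetyl on this nitrogen stays near compound 1 at 100% or falls as far as the two larger groups.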